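Swapping Hydrogen for Fluorine: What Compound 3 Might Show

The source may report more compounds than this note shows. Statements on the series, on what has been measured and on what is new or still open speak of the compounds shown alone.

Compound 1 `COC(=O)c1nc(C)n(-c2ccccc2)n1` gives > 100000 nM in a functional assay on NCI-H226 cells (Homo sapiens) for inhibition, read by MTT assay, with a stated time of 72 h (a higher number here means a weaker inhibitor of growth, a lower number a stronger inhibitor of growth), which is a limit of the assay rather than a number.
Compound 2 `COC(=O)c1nc(C)n(-c2cccc(C(F)(F)F)c2)n1` gives 14300 nM in this assay.

Compound 1 therefore stands only at a bound: the value shown is the limit (the limit of > 100000 nM in this assay, at which 1 of the 2 values shown sits), and no number is known for it. Among the compounds with values here, the one measured step, trifluoromethyl in place of hydrogen on an aromatic carbon, gave an at least 6.9-fold lower number from compound 1 to compound 2 (0.84 log units; beyond the scatter). Compound 3 `COC(=O)c1nc(C)n(-c2ccc(F)cc2)n1` is the unmeasured partner, differing from compound 1 by fluoro in place of hydrogen on an aromatic carbon. Within the data shown here, only the step from compound 1 to compound 2 bears on this change, and fluoro is a much smaller group than trifluoromethyl, so a weaker effect is expected, possibly none beyond the scatter. Compound 3 is therefore expected to give 80000 nM, between 30000 nM and 200000 nM, which is an expected step of an at least 1.2-fold lower number from compound 1 to compound 3 (0.09 log units; that floor lies within the scatter).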

Compound 3, concentration for 50% growth inhibition: 11700 nM
Beside the measured number, compound 3's estimate is 6.8-fold (0.83 log units) above it, and the stated range ends above it.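

Fluoro in place of hydrogen on an aromatic carbon, para to a large group, gives an at least 8.5-fold lower number from compound 1 to compound 3 (0.93 log units; beyond the scatter). Within the data shown here, this adds only one heavy atom, so the earlier step with trifluoromethyl is no longer the only change on this six-membered aromatic ring known to lower the number beyond the scatter. As far as these compounds go, the true size of the new step stays open, since the value for compound 1 is a limit and not a number: the limit of > 100000 nM in this assay, at which 1 of the 3 values shown sits.

The compounds shown leave open whether this step belongs to fluoro itself or would also appear with other groups at the same carbon, such as chloro, an amine or a carboxylic acid. They also do not tell how fluoro would fare on another carbon of the same ring.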